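The source may report more compounds than this note shows. Statements on the series, on what has been measured and on what is new or still open speak of the compounds shown alone.

In a functional assay on K562 cells (Homo sapiens) for cytotoxicity, read by MTT assay, with a stated time of 5 days (a higher number here means a weaker inhibitor, a lower number a stronger inhibitor), compound 1 (`COc1ccc(Cn2nncc2-c2cc(OC)c(OC)c(OC)c2)cc1Br`) reads > 10000 nM, which is a limit of the assay and not a number. Compound 2 (`COc1ccc(Cn2nncc2-c2cc(OC)c(OC)c(OC)c2)cc1O`) gives 1830 nM. As far as these compounds go, compound 3 (`COc1ccc(Cn2cc(-c3cc(OC)c(OC)c(OC)c3)nn2)cc1Br`) reads > 10000 nM, also only a limit, so its exact place on the scale is unknown. Compound 4 (`COc1ccc(Cn2cc(-c3cc(OC)c(OC)c(OC)c3)nn2)cc1[N+](=O)[O-]`) carries nitro in place of bromo on an aromatic carbon. The nearest measured change is an at least 5.4-fold lower number from compound 1 to compound 2 (0.73 log units; beyond the scatter), but there hydroxy replaces bromo, and on a differently arranged core. It offers only weak guidance for nitro, so a smaller move towards a lower number is expected, an estimated at least 1.8-fold lower number from compound 3 to compound 4 (0.25 log units; that floor lies within the scatter). For compound 4 the expected value is 5500 nM, with an estimated range from 2000 nM to 10000 nM.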

Compound 4, half-maximal inhibitory concentration: > 10000 nM
Compound 4 ended at the assay's limit; the forecaster's own chance of this, stated with the estimate: 55%; middle value at least 1.8-fold (0.25 log units) from the limit.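

Compound 3 and compound 4 both stand at a limit of the assay, not at a number, so the step from bromo to nitro cannot be read: the limit of > 10000 nM in this assay, at which 3 of the 4 values shown sit.

In this assay the compounds shown leave open whether nitro and bromo differ at all on this core.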